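The source may hold more compounds than are shown below. What is called first, only, known or untested is meant among the compounds shown, and "the series" means these compounds.

Compound 1, `COc1cc(-c2cc(/C=C/C(=O)c3ccc(N)cc3)[nH]n2)cc(OC)c1OC`: > 100000 nM
Compound 2, `COc1ccc(-c2cc(/C=C/C(=O)c3ccc(N)cc3)[nH]n2)cc1OC`: > 100000 nM
Compound 3, `COc1cc(C(=O)/C=C/c2cc(-c3cc(OC)c(OC)c(OC)c3)n[nH]2)cc(OC)c1OC`: > 100000 nM

In a functional assay on RPMI-8226 cells (Homo sapiens) for inhibition, read by sulforhodamine B assay, with a stated time of 48 h (on this read-out lower numbers stand for higher toxicity in this test and higher numbers for lower toxicity in this test), compound 1 reaches only a limit of the assay, > 100000 nM, so no number is known for it. Compound 2 likewise gives only a limit, > 100000 nM. Compound 3 also stops at a limit, > 100000 nM. Within the data shown here, the one step that can be drawn between these compounds, a step that the two limits leave unreadable from compound 1 to compound 2, cannot be read for that reason, and the limit of > 100000 nM in this assay, at which 3 of the 3 values shown sit, is all the three results have in common. Compound 4, `COc1cc(-c2cc(/C=C/C(=O)c3ccc(F)c(F)c3)[nH]n2)cc(OC)c1OC`, is not yet measured. It differs from compound 1 in one place: 3,4-difluorophenyl in place of 4-aminophenyl on a carbonyl carbon. Among the measured compounds shown here, no measured step touches this change, so nothing among the values shown says whether it moves the result in this assay in either direction, or by how much. For the measured compounds named here, the only guide is that every compound so far sits at the limit, and compound 4 is expected to behave the same, its result most likely being a limit again. The step that the limit leaves unreadable from compound 1 to compound 4 is expected to stay within the scatter. The estimate for compound 4 is 120000 nM, with a range from 30000 nM to 400000 nM.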

Compound 4, concentration lethal to 50% of the cells: > 100000 nM
Compound 4 ended at the assay's limit; the forecaster's own chance of this, stated with the estimate: 75%; the middle value does not contradict the limit.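

Compound 1 and compound 4 each give only a limit in this assay, so the step from 4-aminophenyl to 3,4-difluorophenyl cannot be read, and neither can any other step here: the limit of > 100000 nM in this assay, at which 4 of the 4 values shown sit.

The compounds shown leave open whether any of these changes moves the result in this assay at all, and in which direction.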